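Ortho Amino on the Phenyl Ring of Compound 1

The source may report more compounds than this note shows. Statements on the series, on what has been measured and on what is new or still open speak of the compounds shown alone.

Of the compounds shown here, three of one family have been measured in an assay on membranes from brain for binding affinity to adenosine receptor A1 (Rattus norvegicus), read by radioligand binding; a lower number here means a stronger inhibitor, a higher number a weaker inhibitor. Compound 1 `Cc1nn(C)c2c(O)nc(-c3ccccc3)nc12` gives 1020 nM. Compound 2 `Cc1nn(C)c2c(O)nc(-c3ccc(Cl)cc3)nc12` carries a chloro group on its phenyl ring and gives 410 nM. Compound 3 `Cc1ccc(-c2nc(O)c3c(n2)c(C)nn3C)cc1` carries a methyl group there instead and gives 400 nM. Compound 1 thus has the highest number of the three: the step of a 2.5-fold lower number from compound 1 to compound 2 (0.40 log units; beyond the scatter) and the step of a 2.6-fold lower number from compound 1 to compound 3 (0.41 log units; beyond the scatter) both go to a lower number, while compound 2 and compound 3 sit within the scatter of each other, as the step of a 1.0-fold lower number from compound 2 to compound 3 (0.01 log units; within the scatter) shows.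

Compound 4 `Cc1nn(C)c2c(O)nc(-c3ccccc3N)nc12` is not yet measured. It differs from compound 1 in one place: amino in place of hydrogen on an aromatic carbon. Of the measured steps, those from compound 1 to compound 2 and to compound 3 bear on it, as both also add a single group to an otherwise bare phenyl ring of compound 1, and both were modest. Among the measured compounds shown here, the new group sits ortho to a large group, a place none of the measured compounds probe, so the expectation is only a modest step or none beyond the scatter. The estimated step is a 1.5-fold lower number from compound 1 to compound 4 (0.16 log units; within the scatter), so compound 4 is expected to give 700 nM in this assay, within a range from 250 nM to 2500 nM.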

Compound 4, half-maximal inhibitory concentration: 230 nM
Compound 4: middle estimate off by 3.0-fold (0.48 log units), on the high side, outside the stated range (below it).
By their numbers in this assay, from the lowest: compounds 4, 3 and 2 (each within the scatter of the next); then compound 1.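

In this assay, the place ortho to a large group on the phenyl ring accepts a new group, and the change runs toward a stronger inhibitor: amino in place of hydrogen brings a 4.4-fold lower number from compound 1 to compound 4 (0.65 log units; beyond the scatter). Among the compounds shown here, the earlier compounds carried their added groups at a different place on that ring, so this is the first sign that this place also responds to substitution, with a step that lies beyond the scatter rather than a flat result. Nothing at hand bears on why an amino group here lowers the number, so the step stands as an observation only.

The compounds shown cannot tell whether this step belongs to the amino group itself or would appear with any group at this place, and a hydroxyl, methoxy or methylamino group there would help separate those two readings. They also leave open what an amino group would do at the place that holds the chloro group of compound 2 and the methyl group of compound 3.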